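Chloro Substitution on the Aryloxy Ring and Cytotoxicity

The compounds below may be only part of what the source reports. "The series", "measured", "known", "first", "only" and "open" are said of these compounds alone.

Compound 1 `NC(=S)N/N=C(/COc1ccc(Br)cc1)c1ccccc1` and compound 2 `NC(=S)N/N=C(/COc1ccc(Br)cc1)c1ccc(Cl)cc1` share one core, while compound 3 `NC(=S)N/N=C(\COc1ccc(F)cc1)c1ccc(Br)cc1` and compound 4 `NC(=S)N/N=C(\COc1ccc(F)c(Cl)c1)c1ccc(Br)cc1` share another; the difference between the two cores is not broken down here. In an ADME assay on L929 cells (Mus musculus) for cytotoxicity, read by resazurin assay, with a stated time of 96 h (on this read-out lower numbers stand for higher toxicity in this test and higher numbers for lower toxicity in this test), compound 1 gives only a limit, < 27500 nM. In this assay compound 2 gives 25100 nM. Compound 2 differs from compound 1 by chloro in place of hydrogen on an aromatic carbon, and the step that the limit leaves unreadable from compound 1 to compound 2 cannot be sized because of the limit of < 27500 nM in this assay, at which 1 of the 3 values shown sits. In this assay compound 3 gives 52300 nM, the highest of the two numbers and beyond the scatter from compound 2.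

Compound 4 differs from compound 3 by chloro in place of hydrogen on an aromatic carbon. This is the same kind of change as from compound 1 to compound 2, not the same: in compound 2 the chloro sits para to a large group, whereas in compound 4 it sits ortho to a fluoro group and meta to a large group. Going by the values given here, with the only measured instance of this change unreadable, the expectation rests on compound 3 and its value 52300 nM, and the step of a 1.3-fold lower number from compound 3 to compound 4 (0.12 log units; within the scatter) is expected to stay modest. Compound 4 is therefore estimated at 40000 nM, between 15000 nM and 100000 nM.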

Compound 4, half-maximal cytotoxic concentration: 48000 nM
Compound 4: middle estimate off by 1.2-fold (0.08 log units), on the low side; the measured number falls inside the stated range.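

In this assay the chloro group, entering ortho to a fluoro group and meta to a large group, gives a 1.1-fold lower number from compound 3 to compound 4 (0.04 log units; within the scatter) and so does not tell the two compounds apart. The same change on the core of compound 1 cannot be sized, because compound 1 gives only a limit: the limit of < 27500 nM in this assay, at which 1 of the 4 values shown sits. The series therefore offers a single readable instance of this change, on the core of compound 3, and it does not show whether the result carries over to the core of compound 1, where the chloro of compound 2 also stands in another place.

The compounds shown leave open how a methoxy group, an amine or a carboxylic acid would read at the place the chloro takes in compound 4. They also leave open how the chloro itself would read at other places on the core of compound 3.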